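A Pyridin-4-yl in Place of Thiophen-2-yl

This account rests on a few compounds, and the source may have more. Where it says the series, first, only, none or still open, it means among the compounds named here.

compound 1: `Oc1cccc(-c2cc(-c3ccc(Cl)cc3)nc(-c3cccs3)c2)c1` gives 11600 nM
compound 2: `Oc1cccc(-c2cc(-c3cccc(Cl)c3)nc(-c3cccs3)c2)c1` gives 2650 nM

Compound 1 stands as the higher of the two numbers in a functional assay on DU-145 cells (Homo sapiens) for cytotoxicity, read by CCK-8 assay and cell counting, with a stated time of 2 days; a lower number here means a stronger inhibitor, a higher number a weaker inhibitor; its nearest neighbour is compound 2, reached by a 4.4-fold lower number from compound 1 to compound 2 (0.64 log units; beyond the scatter). Compound 3 `Oc1cccc(-c2cc(-c3ccncc3)nc(-c3ccc(Cl)cc3)c2)c1` has not yet been measured. It differs from compound 1 by pyridin-4-yl in place of thiophen-2-yl on an aromatic carbon. For the measured compounds named here, no measured step bears on this change: the only step known puts 3-chlorophenyl in place of 4-chlorophenyl and leaves the thiophen-2-yl untouched. The effect on this assay is therefore open, and no step beyond the scatter is expected in either direction. Compound 3 is estimated at 10000 nM (range 2500 nM to 40000 nM), meaning an expected 1.2-fold lower number from compound 1 to compound 3 (0.06 log units; within the scatter).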

Compound 3, half-maximal inhibitory concentration: 2510 nM
Estimate against measurement, compound 3: 4.0-fold (0.60 log units) above; the measured number falls inside the stated range.
By their numbers in this assay, from the lowest: compounds 3 and 2 (each within the scatter of the next); then compound 1.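

The position next to the ring nitrogen that holds thiophen-2-yl also affects the result, not only the chlorophenyl group changed earlier: in this assay, pyridin-4-yl brings a 4.6-fold lower number from compound 1 to compound 3 (0.66 log units; beyond the scatter). This change alters the ring size and swaps sulfur for nitrogen at once, so the two changes cannot be told apart here. No measurement is available to explain the step.

On these data alone, it remains open how a plain phenyl or a pyridin-3-yl group would behave at this position. Also open, as far as these compounds go, is whether pyridin-4-yl would give a similar step alongside 3-chlorophenyl.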